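Isopropylcarbonyl in Place of Methyl on the Ring Nitrogen

The source may hold more compounds than are shown below. What is called first, only, known or untested is meant among the compounds shown, and "the series" means these compounds.

Compound 1 `CCCN1C/C(=C\c2ccc(OC)c(OC)c2)C(=O)/C(=C/c2ccc(OC)c(OC)c2)C1` gives 11200 nM in a functional assay on NCI-H1975 cells (Homo sapiens) for cytotoxicity, read by MTT assay, with a stated time of 72 h; on this read-out higher numbers stand for weaker inhibition and lower numbers for stronger inhibition.
Compound 2 `COc1cc(/C=C2\CNC/C(=C\c3cc(OC)c(OC)c(OC)c3)C2=O)cc(OC)c1OC` gives 4000 nM in this assay.
Compound 3 `COc1cc(/C=C2\CN(C)C/C(=C\c3cc(OC)c(OC)c(OC)c3)C2=O)cc(OC)c1OC` gives 1000 nM in this assay.

Of the three measured compounds, compound 3 has the lowest number: compound 2 sits one step away (a 4.0-fold lower number from compound 2 to compound 3 (0.60 log units; beyond the scatter)), and compound 1 is further off still, its number higher as the two values show. Compound 4 `COc1cc(/C=C2\CN(C(=O)C(C)C)C/C(=C\c3cc(OC)c(OC)c(OC)c3)C2=O)cc(OC)c1OC` differs from compound 3 in one place: isopropylcarbonyl in place of methyl on an amine nitrogen in a ring.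

Among the measured compounds shown here, only one measured step bears on this change, and only loosely. Going from compound 2 to compound 3 gave a 4.0-fold lower number from compound 2 to compound 3 (0.60 log units; beyond the scatter), so a change at this nitrogen has moved the number before. Nothing measured tells what an isopropylcarbonyl on that nitrogen does, since the steps to compound 1 and compound 2 involve other groups. The step of a 2.0-fold higher number from compound 3 to compound 4 (0.30 log units; within the scatter) is therefore expected to be modest, most likely toward a higher number. Compound 4 is expected to give 2000 nM, within a range from 600 nM to 7000 nM.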

Compound 4, half-maximal inhibitory concentration: 1900 nM
Beside the measured number, compound 4's estimate is 1.1-fold (0.02 log units) above it; the measured number falls inside the stated range.
By their numbers in this assay, from the lowest: compounds 3 and 4 (each within the scatter of the next); then compound 2; then compound 1.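

The step of a 1.9-fold higher number from compound 3 to compound 4 (0.28 log units; within the scatter) shows that in this assay the ring nitrogen can carry the larger isopropylcarbonyl, with its carbonyl, in place of methyl without the number leaving the usual scatter. The step of a 2.1-fold lower number from compound 2 to compound 4 (0.32 log units; beyond the scatter) adds that isopropylcarbonyl, like methyl, gives a lower number than hydrogen on this nitrogen, so two quite different groups both stand apart from the unsubstituted amine of compound 2. No evidence here says why these groups behave this way.

Still open, from the compounds shown here alone, is whether a smaller acetyl or a ring-bearing benzoyl on this nitrogen would fall in the same range. It is also unknown how a longer chain ending in an amine or a carboxylic acid would fare there.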